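A Second Fluorinated Aryl on the Ring Amine

The source may report more compounds than this note shows. Statements on the series, on what has been measured and on what is new or still open speak of the compounds shown alone.

Of the compounds shown here, three of a shared core have been read in a functional assay on CHO cells with adenosine receptor A1 (Homo sapiens) as the target, read by cAMP accumulation and immunoassay, with a stated time of 6 min, tested at 0.01 uM; a higher number here means a weaker effect of the compound at the concentration tested, a lower number a stronger effect. Compound 1, `Nc1scc(CN2CCN(c3ccccc3C(F)(F)F)CC2)c1C(=O)c1ccc(Cl)cc1`, gives 0% in this assay. Compound 2, `Nc1scc(CN2CCC(c3ccc(Cl)cc3)CC2)c1C(=O)c1ccc(Cl)cc1`, gives 0%, level with compound 1 at the digits shown. Compound 3, `Nc1scc(CN2CCN(c3c(F)cccc3F)CC2)c1C(=O)c1cccc(C(F)(F)F)c1`, gives 2.1%, a number that lies within the scatter of both compound 1 and compound 2, so no order among the three can be read from these numbers; all three sit at the low end of the read-out at the concentration tested.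

Compound 4, `Nc1scc(CN2CCN(c3cccc(F)c3F)CC2)c1C(=O)c1ccc(Cl)cc1`, has not been measured in this assay. It differs from compound 1 in one place: 2,3-difluorophenyl in place of 2-(trifluoromethyl)phenyl on an amine nitrogen in a ring. Going by the values given here, no step between two measured compounds is at hand for this exchange. Compound 3 carries a different difluorophenyl on the same kind of ring amine and gives 2.1%, not beyond the scatter from compound 1. Compound 4 is therefore expected to give 1%, with a range from -5% to 8%. The step of a number 1 percentage points higher from compound 1 to compound 4 (within the scatter) is expected to stay within the scatter, with no direction to it.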

Compound 4, a percentage reported as activity, at one concentration (the size of the read-out at that concentration, not a potency): -13%
Compound 4: middle estimate off by 14 percentage points, on the high side; measured number below the stated range.
By their numbers in this assay, from the lowest: compound 4; then compounds 1, 2 and 3 (each within the scatter of the next).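

In this assay, going by these compounds alone, 2,3-difluorophenyl in place of 2-(trifluoromethyl)phenyl on the amine nitrogen in the ring gives a number 13 percentage points lower from compound 1 to compound 4 (beyond the scatter), the only step so far at this position that is read beyond the scatter. It shows that the aryl group on this ring amine can move the read-out at the concentration tested, and that the change goes towards the lower numbers, which here mean a stronger effect, something the three earlier compounds, all within the scatter of one another, did not show. Nothing at hand gives a cause for this step.

As far as these compounds go, it remains open whether the step depends on the two fluorines or on the loss of the trifluoromethyl group. A phenyl bearing a single fluorine, a chlorine or a methoxy group at this place would help separate these, and a reading over several concentrations would show whether the step holds beyond this single one.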